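This account rests on a few compounds, and the source may have more. Where it says the series, first, only, none or still open, it means among the compounds named here.

Compound 1, `CC(C)c1ccc2c(CCC/C=N\NC(=O)Nc3ccccc3)cc(C(=O)O)c-2cc1`, gives > 100000 nM in a functional assay on thoracic aorta for antagonist activity at thromboxane A2 receptor (Rattus norvegicus) (on this read-out lower numbers stand for stronger inhibition and higher numbers for weaker inhibition), which is a limit of the assay and not a number.
Compound 2, `CC(C)c1ccc2c(CCCC(=O)NS(=O)(=O)c3ccccc3)cc(C(=O)O)c-2cc1`, gives > 100000 nM in this assay, likewise a limit and not a number.

Compound 2 therefore stands at the edge of what this assay can report, and nothing separates it from compound 1 there, since (the limit of > 100000 nM in this assay, at which 2 of the 2 values shown sit). Compound 3, `CC(C)c1ccc2c(CCCC(=O)NS(=O)(=O)c3ccc(Cl)cc3)cc(C(=O)O)c-2cc1`, differs from compound 2 in one place: chloro in place of hydrogen on an aromatic carbon. Among the measured compounds shown here, no pair of measured compounds shows what such a change does here, so there is no measured step to lean on. Compound 3 is expected to stay near the edge of the assay, with the step of a number no higher from compound 2 to compound 3 (the limit leaves the size open) amounting to nothing beyond the usual scatter. In this assay compound 3 is thus estimated at 100000 nM, within a range from 20000 nM to 300000 nM.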

Compound 3, half-maximal inhibitory concentration: 19000 nM
Compound 3: middle estimate off by 5.3-fold (0.72 log units), on the high side; measured number outside the range, below it.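

Among the compounds shown here, compound 3 is the first compound here to give a real number in this assay rather than a limit, so the phenyl on the sulfonyl group proves to be a place where a small change can register. Going from phenyl to 4-chlorophenyl, with the chloro para to a large group, gives an at least 5.2-fold lower number from compound 2 to compound 3 (0.72 log units; beyond the scatter). That step is only a minimum, and its true size stays unknown, because compound 2 gives a limit and not a number: the limit of > 100000 nM in this assay, at which 2 of the 3 values shown sit.

Going by these compounds, what a fluoro, methyl or methoxy group would do at this same carbon remains open, as does the effect of chloro elsewhere on the ring. Also open, on these data alone, is whether chloro on the phenyl of compound 1 would lift that compound off its limit in the same way.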